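A few compounds are considered here, and "the series" means these few. Any claim that something is new, unique, unknown or untested is made for them only; others in the source may bear on it.

Measured so far in a functional assay on A549 cells (Homo sapiens) for cytotoxicity, read by XTT assay, with a stated time of 72 h; on this read-out lower numbers stand for stronger inhibition and higher numbers for weaker inhibition:

Compound 1 `O=C1C=CC(=O)C(c2cc(-c3ccc(C(=O)N4CCCCC4)s3)on2)=C1` gives > 30000 nM, which is a limit of the assay rather than a number.
Compound 2 `CN(Cc1ccc(F)cc1)C(=O)c1ccc(-c2cc(C3=CC(=O)C=CC3=O)no2)s1` gives > 30000 nM, again a limit of the assay and not a number.
Compound 3 `COc1ccc(OC)c(-c2cc(-c3ccc(C(=O)N(C)Cc4ccc(F)cc4)s3)on2)c1` gives > 30000 nM, once more a limit of the assay.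

Compound 1 and compound 2 share one core and differ in a single place: piperidin-1-yl in place of (4-fluorobenzyl)(methyl)amino on a carbonyl carbon. The step between them, a step that the two limits leave unreadable from compound 2 to compound 1, cannot be sized, since each of the two values is only a limit.

Compound 2 and compound 3 differ in their cores: a group of 10 heavy atoms (8 carbon, 2 oxygen; one six-membered aromatic ring of carbon only) in place of a group of 8 heavy atoms (6 carbon, 2 oxygen; one six-membered non-aromatic ring of carbon only), on an aromatic carbon. The step that the two limits leave unreadable from compound 2 to compound 3 is likewise unreadable, for the same reason that both values are limits.

Compound 4 `COc1ccc(OC)c(-c2cc(-c3ccc(C(=O)N4CCCCC4)s3)on2)c1` has not yet been measured in this assay. It differs from compound 3 exactly as compound 1 differs from compound 2: piperidin-1-yl in place of (4-fluorobenzyl)(methyl)amino on a carbonyl carbon. The place of the change is the same in both pairs, so it is the same change made on the core of compound 3 instead of the core of compound 2.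

What is known about this change on the other core is only that neither partner gave a number, and the same holds for compound 3 itself. That rests on (the limit of > 30000 nM in this assay, at which 3 of the 3 values shown sit). The expected step from compound 3 to compound 4 in this assay is therefore put at a step that the limit leaves unreadable from compound 3 to compound 4, and most likely this assay will again report only a limit. Compound 4 is estimated at 45000 nM, with a range from 15000 nM to 150000 nM.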

Compound 4, half-maximal inhibitory concentration: > 30000 nM
Compound 4: a limit, no number (the forecaster's own chance of this, stated with the estimate: 85%); the middle value does not contradict the limit.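

In this assay compound 4 gives > 30000 nM, which is a limit of the assay and not a number. Compound 3 also has only a limit, so the step between compound 3 and compound 4 cannot be read. The compounds shown leave open whether either structural change affects cytotoxicity at all, as every result rests on the same boundary: the limit of > 30000 nM in this assay, at which 4 of the 4 values shown sit.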